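The compounds below may be only part of what the source reports. "The series", "measured", "known", "first", "only" and "open" are said of these compounds alone.

Measured compounds:
compound 1 `Nc1ccccc1-c1cc(F)cc(-n2nnc(-c3ccccn3)n2)c1` with 7 nM
compound 2 `Cc1cccnc1-c1cc(F)cc(-n2nnc(-c3ccccn3)n2)c1` with 24 nM
compound 3 `Cc1cnccc1-c1cc(F)cc(-n2nnc(-c3ccccn3)n2)c1` with 33 nM

In an assay for binding affinity to metabotropic glutamate receptor 5 (Rattus norvegicus) (a higher number here means a weaker inhibitor, a lower number a stronger inhibitor), compound 3 has the highest number of the three. It stands nearest to compound 2, a step of a 1.4-fold higher number from compound 2 to compound 3 (0.14 log units; within the scatter), and furthest from compound 1, where the step is a 4.7-fold higher number from compound 1 to compound 3 (0.67 log units; beyond the scatter). Compound 4 `Cc1cncc(-c2cc(F)cc(-n3nnc(-c4ccccn4)n3)c2)c1` has not yet been measured in this assay. It differs from compound 3 in one place: 5-methylpyridin-3-yl in place of 3-methylpyridin-4-yl on an aromatic carbon.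

For the measured compounds named here, only one measured step concerns the same kind of change, an exchange of one methylpyridinyl group for another: the step of a 1.4-fold higher number from compound 2 to compound 3 (0.14 log units; within the scatter), which lies within the scatter. The larger steps of a 3.4-fold higher number from compound 1 to compound 2 (0.54 log units; beyond the scatter) and a 4.7-fold higher number from compound 1 to compound 3 (0.67 log units; beyond the scatter) involve the replacement of the 2-aminophenyl group and bear less directly on the present change. The step from compound 3 to compound 4 is therefore expected to stay within the scatter, with no clear direction: a 1.1-fold higher number from compound 3 to compound 4 (0.03 log units; within the scatter). Compound 4 is accordingly expected to give 35 nM in this assay, with a range from 12 nM to 110 nM.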

Compound 4, inhibition constant: 272 nM
Beside the measured number, compound 4's estimate is 7.8-fold (0.89 log units) below it; the measured number lies above the stated range.
By their numbers in this assay, from the lowest: compound 1; then compounds 2 and 3 (each within the scatter of the next); then compound 4.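

Within this assay, the methylpyridinyl groups at this place on an aromatic carbon are not interchangeable: the earlier exchange, a 1.4-fold higher number from compound 2 to compound 3 (0.14 log units; within the scatter), stayed within the scatter, but 5-methylpyridin-3-yl, with the same atoms joined differently, brings an 8.2-fold higher number from compound 3 to compound 4 (0.92 log units; beyond the scatter) and an 11-fold higher number from compound 2 to compound 4 (1.05 log units; beyond the scatter). Set against the 2-aminophenyl group, the same replacement gives a 39-fold higher number from compound 1 to compound 4 (1.59 log units; beyond the scatter), the largest step among these compounds, so the affinity at this place depends on how the pyridine ring is arranged and not only on the presence of a methylpyridinyl group. The information available offers no explanation for the loss seen with this arrangement.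

All three pyridine compounds carry a methyl group, so the compounds shown cannot separate the contribution of that methyl from the point of attachment and the location of the ring nitrogen. As far as these compounds go, it also remains open whether an unsubstituted pyridin-3-yl group, or a pyridin-3-yl group bearing an amine in place of the methyl, would stay close to compound 4 or come nearer to compound 1.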